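Replacing 3-Chlorophenyl with 4-Methylphenyl: An Expected Value

The source may report more compounds than this note shows. Statements on the series, on what has been measured and on what is new or still open speak of the compounds shown alone.

Measured compounds in a functional assay on HL-60 cells (Homo sapiens) for antiproliferative activity, read by sulforhodamine B assay, with a stated time of 72 h; on this read-out lower numbers stand for stronger inhibition and higher numbers for weaker inhibition:
Compound 1 `S=C(N/N=C/c1ccc2ccccc2n1)Nc1cccc(Cl)c1` gives 28800 nM.
Compound 2 `NC(=S)N/N=C/c1cc2ccccc2s1` gives > 100000 nM, which is a limit of the assay and not a number.
Compound 3 `Cc1csc2sc(/C=N/NC(N)=S)c(C)c12` gives > 100000 nM, also a limit of the assay rather than a number.

Within the data shown here, compound 1 is thus the only compound here with an actual number; the two others sit at the limit of > 100000 nM in this assay, at which 2 of the 3 values shown sit, so no step between measured compounds can be sized, and nothing can be said about the order of compound 2 and compound 3 relative to each other. Compound 4 `Cc1ccc(NC(=S)N/N=C/c2ccc3ccccc3n2)cc1` has not been measured. It differs from compound 1 in one place: 4-methylphenyl in place of 3-chlorophenyl on an amide-type nitrogen. Among the measured compounds shown here, no measured pair here shows what such a change does, so the expectation rests on compound 1 alone. Compound 4 is expected to stay close to compound 1, with the step of a 1.2-fold higher number from compound 1 to compound 4 (0.08 log units; within the scatter) expected to fall within the usual scatter or only modestly beyond it, in either direction. The estimate for compound 4 in this assay is therefore 35000 nM, with a range from 10000 nM to 100000 nM, and a real chance that the assay reports only a limit.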

Compound 4, half-maximal inhibitory concentration: 78300 nM
Beside the measured number, compound 4's estimate is 2.2-fold (0.35 log units) below it; low and high end bracket the measured number.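

In this assay, among these compounds, putting 4-methylphenyl in place of 3-chlorophenyl on the amide-type nitrogen gives a 2.7-fold higher number from compound 1 to compound 4 (0.43 log units; beyond the scatter), the first step here that can be sized, and it points towards weaker inhibition. The two groups match in what can be counted: each has 7 heavy atoms and one six-membered aromatic ring of carbon only, with no hydrogen-bond donors or acceptors, so even a swap this close to like-for-like moves the number beyond the usual scatter at this position. Steps to compound 2 and compound 3 still cannot be read, as both give only a limit and not a number: the limit of > 100000 nM in this assay, at which 2 of the 4 values shown sit.

This single step changes both the atom on the ring (chlorine to a methyl carbon) and where the group is named on the ring, so a 3-methylphenyl or a 4-chlorophenyl group would be needed to tell those two changes apart. Also open, as far as these compounds go, is how a plain phenyl ring, or a phenyl ring carrying an amine or a carboxylic acid, would read in this assay, and whether any group at this nitrogen can give a lower number than compound 1.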